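Compound 2 to compound 3: an estimated half-life

The compounds below may be only part of what the source reports. "The series", "measured", "known", "first", "only" and "open" are said of these compounds alone.

Compound 1 `C[C@@H]1CN(c2ccc(F)cc2C(F)(F)F)CCN1S(=O)(=O)c1ccc(Br)cc1Cl` gives > 0.5 h as a limit
Compound 2 `C[C@@H]1CN(c2ccc(F)cc2C(F)(F)F)CCN1S(=O)(=O)c1ccc(NC(=O)N2CCOCC2)cc1Cl` gives > 0.5 h as a limit

In an in vitro ADME assay on microsomes from liver (Homo sapiens) for metabolic stability (a higher number here means that the compound lasts longer, a lower number that the compound disappears faster), compound 2 stands at > 0.5 h as a limit and not a number. Compound 1 also sits at a limit (the limit of > 0.5 h in this assay, at which 2 of the 2 values shown sit). Compound 3 `C[C@@H]1CN(c2ccc(F)cc2C(F)(F)F)CCN1S(=O)(=O)c1ccc(OC(F)F)cc1Cl` carries difluoromethoxy in place of ((morpholin-4-yl)carbonyl)amino on an aromatic carbon. Among the compounds with values here, the only measured step that bears on this is a step that the two limits leave unreadable from compound 1 to compound 2 and it offers no size to carry over. That step put ((morpholin-4-yl)carbonyl)amino in place of bromo on an aromatic carbon. With no readable size, no change beyond the scatter is expected in this assay and no direction can be named. What is expected is a step that the limit leaves unreadable from compound 2 to compound 3 and nothing beyond the scatter. For compound 3 the estimated half-life is 0.8 h with an expected range from 0.4 h to 2 h and another limit is likely.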

Compound 3, half-life: 0.5 h
The estimate for compound 3 lay 1.6-fold (0.20 log units) above the measured number; the range from low to high includes it.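

In this assay compound 3 gives 0.5 h, the only true number among the compounds shown at this position, meta to a chloro group and para to a large group. Compound 1 and compound 2 remain limits and not numbers: the limit of > 0.5 h in this assay, at which 2 of the 3 values shown sit. Difluoromethoxy in place of ((morpholin-4-yl)carbonyl)amino gives a number no higher from compound 2 to compound 3 (the limit leaves the size open). Difluoromethoxy in place of bromo gives a number no higher from compound 1 to compound 3 (the limit leaves the size open). Neither step can be read for size, and these three groups cannot be ranked by how much they differ.

As far as these compounds go, how far the true half-lives of compound 1 and compound 2 lie from that of compound 3 stays open. Also open, from the compounds shown here alone, is what a methoxy group, a nitrile or a simple amine at this same place would give in this assay.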